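Five-membered ring swap at the aryl position: furan to thiophene

A few compounds are considered here, and "the series" means these few. Any claim that something is new, unique, unknown or untested is made for them only; others in the source may bear on it.

Compound 2 `c1coc(-c2ccccc2OCC2=NCCN2)c1` is one of two measured members of the series. In a functional assay for activation of Alpha-1B adrenergic receptor (Homo sapiens), read by calcium flux (a lower number here means a smaller maximal response, a higher number a larger maximal response), compound 2 gives 110%; compound 1 `c1cncc(-c2ccccc2OCC2=NCCN2)c1` gives 111% in this assay. Compound 2 holds the lower of the two numbers, but the difference a number 1 percentage points lower from compound 1 to compound 2 (within the scatter) is within the scatter, so no order between the two can be read from it.

Compound 3 `c1csc(-c2ccccc2OCC2=NCCN2)c1` has not yet been measured. It differs from compound 2 as follows: thiophen-2-yl in place of furan-2-yl on an aromatic carbon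

For the measured compounds named here, the only step known, a number 1 percentage points lower from compound 1 to compound 2 (within the scatter), concerns a different exchange at the same aromatic carbon and left the maximal response essentially unchanged. Because that step a number 1 percentage points lower from compound 1 to compound 2 (within the scatter) was flat, no movement beyond the scatter is expected for the present exchange in this assay either. The estimated step is a number 2 percentage points lower from compound 2 to compound 3 (within the scatter), that is, compound 3 is expected to give about 108% in this assay, with a likely range from 95% to 120%.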

Compound 3, largest response reached (reported as maximum), in percent of the reference or control that the assay uses: 112%
Beside the measured number, compound 3's estimate is 4 percentage points below it; low and high end bracket the measured number.
By their numbers in this assay, from the lowest: compounds 2, 1 and 3 (each within the scatter of the next).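

In this assay, the exchange of the ring oxygen of furan-2-yl for the sulfur of thiophen-2-yl gives a number 2 percentage points higher from compound 2 to compound 3 (within the scatter), so this second exchange at the aromatic carbon is also flat. Thiophen-2-yl in place of pyridin-3-yl gives a number 1 percentage points higher from compound 1 to compound 3 (within the scatter), which means that furan-2-yl, thiophen-2-yl and pyridin-3-yl cannot be told apart by maximal response at this position. No supporting data bear on this result.

Going by these compounds, all three compounds carry an aromatic ring at this carbon, so it remains open whether the maximal response also holds with a non-aromatic group such as a carboxylic acid or a dimethylamino group there. The shared core also stays unchanged throughout, leaving open how far the response depends on any other part of it.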